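Chain-extended 3-oxoamide homoserine lactones and PC-3 cytotoxicity

This account rests on a few compounds, and the source may have more. Where it says the series, first, only, none or still open, it means among the compounds named here.

Compound 1 `O=C(CCCCCCc1ccccc1)N[C@H]1CCOC1=O` carries a plain amide; in a functional assay on PC-3 cells (Homo sapiens) for cytotoxicity, read by sulforhodamine B assay, with a stated time of 5 days (a higher number here means a weaker inhibitor, a lower number a stronger inhibitor), compound 1 reports only a limit, > 100000 nM. Compound 3 `O=C(CCc1ccccc1)CC(=O)N[C@H]1CCOC1=O` carries the 3-oxoamide with a shorter chain; in this assay compound 3 likewise reports only a limit, > 100000 nM. Among the measured compounds shown here, compound 2 `O=C(CCCCCCc1ccccc1)CC(=O)N[C@H]1CCOC1=O` is the one member of the series with a measured number: in this assay compound 2 gives 9000 nM. Compound 2 therefore stands alone among the three values shown, since the other two sit at the limit of > 100000 nM in this assay, at which 2 of the 3 values shown sit, and give no number to compare against.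

Compound 4 `O=C(CCCCCCCCCc1ccccc1)CC(=O)N[C@H]1CCOC1=O` is not yet measured. It differs from compound 2 in one place: 3-phenylpropyl in place of phenyl on a saturated chain carbon, six bonds along the chain from a carbonyl carbon. For the measured compounds named here, because no step between measured compounds is available, the expected size of the step in this assay rests only on what compound 3 and compound 2 show, namely a limit at the shorter chain and a number at the longer one. On that basis a further extension of the chain is expected to move compound 4 toward stronger inhibition, by a moderate step of a 3.0-fold lower number from compound 2 to compound 4 (0.48 log units; beyond the scatter). Compound 4 is estimated at 3000 nM in this assay, with a range from 800 nM to 15000 nM.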

Compound 4, half-maximal inhibitory concentration: 4000 nM
Estimate against measurement, compound 4: 1.3-fold (0.12 log units) below; low and high end bracket the measured number.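

In this assay, among the compounds shown here, 3-phenylpropyl in place of phenyl on a saturated chain carbon, six bonds along the chain from a carbonyl carbon, gives a 2.3-fold lower number from compound 2 to compound 4 (0.35 log units; beyond the scatter), the only step that can be read as a number. The earlier compounds shown here showed activity at this chain length but gave no size for a change at this position; the size is now known to be modest, though beyond the scatter, and the added carbons do not cost activity in this pair. Steps involving compound 1 or compound 3 cannot be read, as each reports only a limit: the limit of > 100000 nM in this assay, at which 2 of the 4 values shown sit.

As far as these compounds go, whether a still longer chain lowers the number further, levels off or reverses the trend remains open, as does the shape of the chain dependence between compound 3 and compound 2. Also open, from the compounds shown here alone, is whether the terminal phenyl is needed at all, for example whether a carboxylic acid or an amine at the end of the chain in its place would keep a measurable number in this assay.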